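This account rests on a few compounds, and the source may have more. Where it says the series, first, only, none or still open, it means among the compounds named here.

Compound 2 `O=c1oc2c(O)cccc2cc1-c1cccs1` gives 1430 nM in an assay on CHO cells for displacement of a labelled ligand from transmembrane domain-containing protein TMIGD3 (Homo sapiens); on this read-out lower numbers stand for stronger inhibition and higher numbers for weaker inhibition. For the measured compounds named here, it is one of only two compounds measured; the other, compound 1 `CC(=O)Oc1cccc2cc(-c3cccs3)c(=O)oc12`, gives 2580 nM in this assay, and the two do not differ beyond the scatter: a 1.8-fold lower number from compound 1 to compound 2 (0.26 log units; within the scatter). Compound 3 `O=c1oc2c(O)cccc2cc1-c1cc(Br)cs1` differs from compound 2 by bromo in place of hydrogen on an aromatic carbon. Going by the values given here, the single measured step alters a different part of the molecule, so no step in hand bears on this change, and no shift beyond the scatter is expected. Compound 3 is therefore estimated at 1200 nM, with a range from 400 nM to 3600 nM. This estimate corresponds to an expected step of a 1.2-fold lower number from compound 2 to compound 3 (0.08 log units; within the scatter).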

Compound 3, inhibition constant: 746 nM
Compound 3: the middle estimate sits 1.6-fold (0.21 log units) above what was measured, and the stated range covers the measured number.
By their numbers in this assay, from the lowest: compounds 3, 2 and 1 (each within the scatter of the next, the first and the last beyond it).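

The earlier step changed only the acetyl on an oxygen, whereas this one shows that the five-membered ring can carry a bromine atom, two ring bonds from the ring sulfur, with no shift beyond the scatter in this assay: a 1.9-fold lower number from compound 2 to compound 3 (0.28 log units; within the scatter). No independent measurement bears on why this change behaves as it does.

From the compounds shown here alone, whether another group on this carbon, such as methyl, an amine or a carboxylic acid, would move the number beyond the scatter remains open. So does the effect of bromo on the ring's other carbons.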